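A few compounds are considered here, and "the series" means these few. Any claim that something is new, unique, unknown or untested is made for them only; others in the source may bear on it.

In a functional assay on MGC-803 cells (Homo sapiens) for antiproliferative activity, read by MTT assay, with a stated time of 48 h (a lower number here means that less compound is needed, a higher number that more compound is needed for the effect), compound 3 (`CC1=NN(S(=O)(=O)c2ccc(F)cc2)C(c2cc(Br)ccc2O)C1`) gives 15500 nM, the lowest of the three numbers measured, though within the scatter of compound 2 (`CC1=NN(S(=O)(=O)c2ccc([N+](=O)[O-])cc2)C(c2cc(Br)ccc2O)C1`) at 22200 nM. Compound 1 (`CC1=NN(C(=O)c2ccc(F)cc2)C(c2ccccc2O)C1`) reads higher at 35400 nM. Compound 4 (`CC1=NN(S(=O)(=O)c2ccccc2I)C(c2cc(Br)ccc2O)C1`) has 2-iodophenyl in place of 4-fluorophenyl on a sulfonyl sulfur. Among the compounds with values here, the only measured step that bears on this group is a 1.4-fold lower number from compound 2 to compound 3 (0.16 log units; within the scatter), with fluoro in place of nitro on an aromatic carbon, and it stayed within the scatter. Within the data shown here, no measured compound carries 2-iodophenyl, so the data give no direction, and no step beyond the scatter is expected in this assay. The estimated step is a 1.0-fold lower number from compound 3 to compound 4 (0.01 log units; within the scatter). Compound 4 is expected at about 15000 nM, with an estimated range of 6000 nM to 35000 nM.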

Compound 4, half-maximal effective concentration: 52500 nM
For compound 4 the middle estimate is 3.5-fold (0.54 log units) below the measured one; measured number above the stated range.
By their numbers in this assay, from the lowest: compounds 3, 2, 1 and 4 (each within the scatter of the next, the first and the last beyond it).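

In this assay, within the data shown here, the aryl group on the sulfonyl sulfur proved not to be indifferent to change: a 3.4-fold higher number from compound 3 to compound 4 (0.53 log units; beyond the scatter), the first step at this position to pass beyond the scatter. The two groups match in heavy atom count and in their lack of hydrogen-bond donors and acceptors, yet they do not read alike. The swap of 4-fluorophenyl for 2-iodophenyl alters both the halogen and its ring position, so the step cannot be assigned to either alone, and a 4-iodophenyl or an aminophenyl group on the sulfur remains an open comparison. Nothing available here explains the step.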